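Removing the tert-butyl group from compound 3

The source may report more compounds than this note shows. Statements on the series, on what has been measured and on what is new or still open speak of the compounds shown alone.

Values in a functional assay for inhibition, with Homo sapiens as the target; a lower number here means a stronger inhibitor, a higher number a weaker inhibitor:
Compound 1 `O=C(O)COc1cccc(/C=C/c2nc(-c3ccccc3)c(-c3ccccc3)o2)c1`: 13000 nM
Compound 2 `CCOC(=O)/C(=C\c1cccc(OCC(=O)OC)c1)c1nc(-c2ccccc2)c(-c2ccccc2)o1`: 2000 nM
Compound 3 `CCOC(=O)/C(=C\c1cccc(OCC(=O)OC(C)(C)C)c1)c1nc(-c2ccccc2)c(-c2ccccc2)o1`: > 60000 nM (a limit, not a number)
Compound 4 `CCOC(=O)/C(=C\c1cccc(OCC(=O)O)c1)c1nc(-c2ccccc2)c(-c2ccccc2)o1`: not yet measured

Compound 3 stands at the limit of > 60000 nM in this assay, at which 1 of the 3 values shown sits, and this is a limit rather than an exact reading.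

The change to compound 4 puts hydrogen in place of tert-butyl on an oxygen next to a carbonyl group. Read one bond further out, this is tert-butoxycarbonyl to carboxy.

Among the measured compounds shown here, one measured step touches the same oxygen, and it shows an at least 30-fold higher number from compound 2 to compound 3 (1.47 log units; beyond the scatter). This large step is the main guide here, although it swaps methyl for tert-butyl and does not involve hydrogen. Compound 1 also has hydrogen on that oxygen and gives 13000 nM, but it differs from compound 4 elsewhere in the molecule, so it is only a loose guide.

With tert-butyl gone, a large step to a lower number is expected, placing compound 4 in the region of compound 2 at 2000 nM. The estimated change is an at least 40-fold lower number from compound 3 to compound 4 (1.60 log units; beyond the scatter). For compound 4 the estimate is 1500 nM, with an expected range from 200 nM to 10000 nM.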

Compound 4, half-maximal inhibitory concentration: 360 nM
For compound 4 the middle estimate is 4.2-fold (0.62 log units) above the measured one; the range from low to high includes it.
By their numbers in this assay, from the lowest: compound 4; then compound 2; then compound 1. At a limit, above all of these: compound 3.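

In this assay, putting hydrogen in place of tert-butyl on this oxygen gives an at least 160-fold lower number from compound 3 to compound 4 (2.22 log units; beyond the scatter), which shows that the large loss seen with tert-butyl is not a feature of the shared core, since the core still gives a strong result once that group is gone. The methyl group also proves not to be the best choice here, as hydrogen in its place gives a 5.6-fold lower number from compound 2 to compound 4 (0.74 log units; beyond the scatter), a modest step that is still beyond the scatter, so among the three groups seen on this oxygen the number rises from hydrogen through methyl to tert-butyl. The size of the first step is only a minimum, since compound 3 is known only as a limit and not as a number: the limit of > 60000 nM in this assay, at which 1 of the 4 values shown sits.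

Going by these compounds, whether the number climbs steadily with the size of the group on this oxygen stays open, since an ethyl or isopropyl group there would be needed to fill the gap between hydrogen and tert-butyl. On these data alone, it is also open whether the carboxy group itself is needed, or whether an amide or a tetrazole could stand in its place with a similar result.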